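Moving the bromine on two related cores

This account rests on a few compounds, and the source may have more. Where it says the series, first, only, none or still open, it means among the compounds named here.

Four compounds are compared in a functional assay on MDA-MB-231 cells (Homo sapiens), read by microscopy and transwell migration, with a stated time of 24 h; a higher number here means a weaker inhibitor, a lower number a stronger inhibitor. Compound 1 `O=C(Nc1nc(-c2cccc(Br)c2)cs1)c1ccccc1` gives 10000 nM in this assay, and compound 2 `O=C(Nc1nc(-c2ccc(Br)cc2)cs1)c1ccccc1` gives 9500 nM. The change between them, (4-bromophenyl in place of 3-bromophenyl on an aromatic carbon), produced a 1.1-fold lower number from compound 1 to compound 2 (0.02 log units; within the scatter), so the two cannot be told apart by this read-out.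

Compound 3 `Cn1c(-c2cccc(Br)c2)cs/c1=N\C(=O)c1ccccc1` is built on a different core; the difference between the two cores is not broken down here. In this assay compound 3 gives 302 nM, the lowest number of the three measured compounds, and its gap to compound 2 and to compound 1 lies well beyond the scatter.

Compound 4 `Cn1c(-c2ccc(Br)cc2)cs/c1=N\C(=O)c1ccccc1` has not yet been measured. It differs from compound 3 by 4-bromophenyl in place of 3-bromophenyl on an aromatic carbon, the same kind of change that links compound 1 to compound 2, though the surroundings differ: in compound 3 the carbon that carries the change is next to the ring atom that bears a methyl group (1 heavy atom), whereas in compound 1 it is two ring bonds from the ring atom that bears a group of 9 heavy atoms. Because a 1.1-fold lower number from compound 1 to compound 2 (0.02 log units; within the scatter) stayed within the scatter, the step from compound 3 to compound 4 is expected to be a 1.1-fold higher number from compound 3 to compound 4 (0.03 log units; within the scatter). Compound 4 is therefore estimated at 320 nM in this assay, expected to fall between 120 nM and 850 nM.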

Compound 4, half-maximal inhibitory concentration: 125 nM
Beside the measured number, compound 4's estimate is 2.6-fold (0.41 log units) above it, and the stated range covers the measured number.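

In this assay, moving the bromine from 3-bromophenyl to 4-bromophenyl on the core of compound 3 gave a 2.4-fold lower number from compound 3 to compound 4 (0.38 log units; beyond the scatter), a modest step that, unlike the one on the core of compound 1, lies beyond the scatter. Even so, the two steps cannot be separated when they are set side by side: the same change on two cores in this assay, a 1.1-fold lower number (0.02 log units; within the scatter) from compound 1 to compound 2 and a 2.4-fold lower number (0.38 log units; beyond the scatter) from compound 3 to compound 4, 2.3-fold (0.36 log units) apart, within the scatter of two such steps. Among these compounds, this shows that nothing measured so far sets the two cores apart in their response to this change, but it does not show that the change has the same size on both, and two pairs of compounds say nothing about any further core.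

The compounds shown leave open how the phenyl ring would respond to a group other than bromine, such as chlorine, methoxy or a carboxylic acid, in the same two places. They also leave open whether an ethyl group or a longer chain on the ring atom that bears the methyl group in compound 3 and compound 4 would keep the numbers seen with the methyl group.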